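Diethylcarbamoyl in place of the prenyl-type chain

The source may hold more compounds than are shown below. What is called first, only, known or untested is meant among the compounds shown, and "the series" means these compounds.

Measured in a functional assay on liver (Rattus norvegicus, strain Sprague-Dawley) for inhibition, with a stated time of 1 h; a higher number here means a weaker inhibitor, a lower number a stronger inhibitor:
- compound 1 `CCN(CC)C(=O)COc1cc(O)c2c(=O)c(O)c(-c3ccc4c(c3)OC(c3ccc(OCC(=O)N(CC)CC)c(OC)c3)C(CO)O4)oc2c1`: 5800 nM
- compound 2 `COc1cc(C2Oc3cc(-c4oc5cc(OCC=C(C)C)cc(O)c5c(=O)c4O)ccc3OC2CO)ccc1O`: 23300 nM

Of these two, compound 2 has the higher number at 23300 nM, so it is the weaker inhibitor in this assay, and its gap to compound 1 lies beyond the scatter.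

Compound 3 `CCN(CC)C(=O)COc1cc(O)c2c(=O)c(O)c(-c3ccc4c(c3)OC(c3ccc(O)c(OC)c3)C(CO)O4)oc2c1` is still to be measured. It differs from compound 2 by diethylcarbamoyl in place of 2-methylprop-1-en-1-yl on a saturated chain carbon bound to an oxygen on an aromatic ring.

Within the data shown here, no measured pair isolates this change. Among the measured compounds shown here, the only guide is compound 1 at 5800 nM, which also carries diethylcarbamoyl. A modest step toward a lower number is therefore expected, near the edge of the scatter, and the estimated step is a 2.1-fold lower number from compound 2 to compound 3 (0.33 log units; beyond the scatter). For compound 3 the estimated value is 11000 nM, with an expected range of 4000 nM to 30000 nM.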

Compound 3, half-maximal inhibitory concentration: 700 nM
Beside the measured number, compound 3's estimate is 16-fold (1.20 log units) above it; measured number below the stated range.
By their numbers in this assay, from the lowest: compound 3; then compound 1; then compound 2.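

In this assay, diethylcarbamoyl in place of 2-methylprop-1-en-1-yl on a saturated chain carbon bound to an oxygen on an aromatic ring gives a 33-fold lower number from compound 2 to compound 3 (1.52 log units; beyond the scatter) and is a large step, so this change alone moves the number strongly, which compound 1 could not show with its second difference from compound 2. Hydrogen in place of (diethylcarbamoyl)methyl on an oxygen on an aromatic ring gives an 8.3-fold lower number from compound 1 to compound 3 (0.92 log units; beyond the scatter) and makes compound 3 the strongest inhibitor of the three, so the group does not lower the number at both oxygens. Nothing on hand explains either step.

Still open, as far as these compounds go, is whether the lower number needs the diethylcarbamoyl amide, or whether a carboxylic acid, a dimethylcarbamoyl or a simple ethyl chain on the same oxygen would do the same. Also open, from the compounds shown here alone, is how an amine-bearing chain or a longer chain carrying the amide would read there.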